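A few compounds are considered here, and "the series" means these few. Any claim that something is new, unique, unknown or untested is made for them only; others in the source may bear on it.

In a functional assay on MOLT-4 cells (Homo sapiens) for antiproliferative activity, with a stated time of 48 h (a higher number here means a weaker inhibitor, a lower number a stronger inhibitor), compound 1 (`C=C(Br)C(=O)Nc1ccc(/C=C/C(=O)c2ccc(F)cc2)cc1`) gives 660 nM and compound 2 (`C=C(Br)C(=O)Nc1ccc(/C=C/C(=O)c2ccc(Cl)cc2)cc1`) gives 810 nM with a 1.2-fold higher number from compound 1 to compound 2 (0.09 log units; within the scatter) as the whole gap between them. Compound 3 (`C=C(Br)C(=O)Nc1ccc(/C=C/C(=O)c2ccc(I)cc2)cc1`) stands at 2800 nM and holds the highest number of the three, which makes it the weakest inhibitor among them.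

Compound 4 (`C=C(Br)C(=O)Nc1ccc(/C=C/C(=O)c2ccc(OC)cc2)cc1`) has not yet been measured. It carries methoxy in place of iodo on an aromatic carbon, para to a large group (methoxy in place of iodo on an aromatic carbon) and is otherwise the same as compound 3. For the measured compounds named here, no measured step brings in methoxy, so the evidence is indirect. Going by the values given here, the steps that bear on the change are the two that end in iodo, namely a 4.2-fold higher number from compound 1 to compound 3 (0.63 log units; beyond the scatter) and a 3.5-fold higher number from compound 2 to compound 3 (0.54 log units; beyond the scatter) and both are modest. Read backwards, they suggest that compound 3 loses ground through its iodo, so removing that group should bring the number down towards those of the other two compounds, though methoxy may not behave like fluoro or chloro. In this assay the expected change is a 2.5-fold lower number from compound 3 to compound 4 (0.41 log units; beyond the scatter) and so a modest one in the direction of stronger inhibition. For compound 4 the estimated value is 1100 nM with an expected range from 400 nM to 3000 nM as its likely span.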

Compound 4, half-maximal inhibitory concentration: 1300 nM
Compound 4: middle estimate off by 1.2-fold (0.07 log units), on the low side, within the range that was stated.
By their numbers in this assay, from the lowest: compounds 1, 2 and 4 (each within the scatter of the next); then compound 3.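

The step of a 2.2-fold lower number from compound 3 to compound 4 (0.33 log units; beyond the scatter) shows that iodo can be replaced at this position, para to a large group, by a group that is not a halogen and that brings two heavy atoms and one hydrogen-bond acceptor, without the number staying where compound 3 left it. Methoxy also lands with the smaller halogens, at a 1.6-fold higher number from compound 2 to compound 4 (0.21 log units; within the scatter) and a 2.0-fold higher number from compound 1 to compound 4 (0.29 log units; within the scatter), so in this assay compound 3 alone stands apart as the weakest of the four, while the other three cannot be ordered, and neither the presence of a halogen nor the heavy-atom count of the group sorts these compounds. The compounds shown carry no measurement that could explain why iodo differs from the other three groups.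

As far as these compounds go, it remains open whether an amine, a carboxylic acid or a longer chain such as ethoxy at this position would stay with compounds 1, 2 and 4 or move towards compound 3. From the compounds shown here alone, it is also open whether a plain hydrogen there would give a number close to these, and whether the same grouping would hold on other cell lines.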